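Nitro in Place of Hydrogen: What to Expect for Compound 4

The source may hold more compounds than are shown below. What is called first, only, known or untested is meant among the compounds shown, and "the series" means these compounds.

Compound 1 `O=C(/C=C/c1ccc2c(c1)B(O)OC2)c1ccccc1` gives 19100 nM in a toxicity assay on WI-38 cells (Homo sapiens) for cytotoxicity, read by MTT assay, with a stated time of 48 h; a lower number here means a stronger inhibitor, a higher number a weaker inhibitor.
Compound 2 `O=C(/C=C/c1ccc2c(c1)B(O)OC2)c1ccc(-c2ccccc2)cc1` gives 18300 nM.
Compound 3 `O=C(/C=C/c1ccc2c(c1)B(O)OC2)c1ccc(Cl)cc1` gives 24700 nM.

Among these three numbers compound 1 stands second highest, closest to compound 2 and furthest from compound 3. Compound 4 `O=C(/C=C/c1ccc2c(c1)B(O)OC2)c1ccc([N+](=O)[O-])cc1` differs from compound 1 by one change: nitro in place of hydrogen on an aromatic carbon. Among the compounds with values here, two measured steps bear on it, both at the same place on the same ring: a 1.0-fold lower number from compound 1 to compound 2 (0.02 log units; within the scatter) and a 1.3-fold higher number from compound 1 to compound 3 (0.11 log units; within the scatter). Neither left the scatter, so substituents at this position have so far made no real difference, and no step beyond the scatter is expected here either. Compound 4 is therefore estimated to give 20000 nM, within a range of 10000 nM to 40000 nM. That estimate means an expected step of a 1.0-fold higher number from compound 1 to compound 4 (0.02 log units; within the scatter).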

Compound 4, half-maximal inhibitory concentration: 39300 nM
The estimate for compound 4 lay 2.0-fold (0.29 log units) below the measured number; the measured number falls inside the stated range.
By their numbers in this assay, from the lowest: compounds 2, 1, 3 and 4 (each within the scatter of the next, the first and the last beyond it).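

Nitro is the first group at this position to move the number in this assay beyond the scatter, with a 2.1-fold higher number from compound 1 to compound 4 (0.31 log units; beyond the scatter) and a 2.1-fold higher number from compound 2 to compound 4 (0.33 log units; beyond the scatter), both modest steps. Against chloro the change stays within the scatter, at a 1.6-fold higher number from compound 3 to compound 4 (0.20 log units; within the scatter), so nitro and chloro cannot be told apart here. No measurement available here explains why nitro shifts the number.

On these data alone, it remains open whether an amine or a carboxylic acid at this same place would shift the number as nitro does. A longer chain there is equally untested in the compounds shown.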